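The source may hold more compounds than are shown below. What is called first, only, known or untested is meant among the compounds shown, and "the series" means these compounds.

In a functional assay on Caco-2 cells (Homo sapiens) for inhibition, read by MTT assay, with a stated time of 48 h (on this read-out higher numbers stand for weaker inhibition and lower numbers for stronger inhibition), compound 1 `Fc1ccc(/C=N/Nc2nc(-c3ccc(C(F)(F)F)cc3)cs2)cc1F` gives 14600 nM and compound 2 `COc1cc(/C=N/Nc2nc(-c3ccccc3)cs2)c(Br)c(Br)c1OC` gives 26500 nM, two values within the scatter of each other. Compound 3 `COc1ccccc1-c1csc(N/N=C/c2cc(OC)c(OC)c(Br)c2Br)n1` reads > 100000 nM, which is a limit and not a number. Compound 4 `Fc1ccc(/C=N/Nc2nc(-c3ccccc3)cs2)cc1F` is compound 1 with hydrogen in place of trifluoromethyl on an aromatic carbon. Among the compounds with values here, the only measured step, an at least 3.7-fold higher number from compound 2 to compound 3 (0.57 log units; beyond the scatter), is a different change, methoxy in place of hydrogen, so it bears only loosely. Compound 2 also carries hydrogen in that place and gives 26500 nM, so no change beyond the scatter is expected. The estimated step is a 1.4-fold higher number from compound 1 to compound 4 (0.14 log units; within the scatter). For compound 4 the expected value is 20000 nM, with an estimated range of 8000 nM to 50000 nM.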

Compound 4, half-maximal inhibitory concentration: 20900 nM
For compound 4 the middle estimate is 1.0-fold (0.02 log units) below the measured one; the measured number falls inside the stated range.
By their numbers in this assay, from the lowest: compounds 1, 4 and 2 (each within the scatter of the next). At a limit, above all of these: compound 3.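

In this assay, within the data shown here, the first matched pair at this position shows that replacing trifluoromethyl with hydrogen on the core of compound 1 stays within the scatter: a 1.4-fold higher number from compound 1 to compound 4 (0.16 log units; within the scatter). In this pair, therefore, the number does not depend on trifluoromethyl at this position. Nothing measured here bears on why this step is so small.

Going by these compounds, whether an amine or a carboxylic acid at this position would move the number beyond the scatter remains open. So does whether hydrogen and trifluoromethyl would also read alike with other substituents on the other aromatic ring.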